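This account rests on a few compounds, and the source may have more. Where it says the series, first, only, none or still open, it means among the compounds named here.

Values in an assay on HEK293 cells for displacement of a labelled ligand from 5-hydroxytryptamine receptor 3A (Homo sapiens), read by scintillation counting, with a stated time of 24 h, in the presence of a further agent that is not named here; on this read-out lower numbers stand for stronger inhibition and higher numbers for weaker inhibition:

compound 1 `CNc1nc(N2CC[C@H](N)C2)nc2ccc(Cl)cc12`: 2340 nM
compound 2 `CNc1nc(NCCC2CCN(C)C2)nc2ccc(Cl)cc12`: 11700 nM
compound 3 `CN1CCN(c2ncc3cc(Cl)ccc3n2)CC1`: 7.41 nM

Compound 3 stands lowest of the three in this assay, with compound 1 nearest and compound 2 furthest, both gaps beyond the scatter. Compound 1 and compound 2 each carry a methylamino group on the shared core but differ from compound 3 in more than one place, so their values show only that both sit far higher.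

Compound 4 `CN1CCN(c2nc(N(C)C)c3cc(Cl)ccc3n2)CC1` differs from compound 3 by dimethylamino in place of hydrogen on an aromatic carbon. For the measured compounds named here, no single measured step of this kind exists, so the size rests on judgement alone. The step in an 8.1-fold higher number from compound 3 to compound 4 (0.91 log units; beyond the scatter) is expected to run toward a higher number, beyond the scatter. Compound 4 is thus estimated at 60 nM, with a range from 10 nM to 500 nM.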

Compound 4, inhibition constant: 6.61 nM
Beside the measured number, compound 4's estimate is 9.1-fold (0.96 log units) above it, and the stated range ends above it.
By their numbers in this assay, from the lowest: compounds 4 and 3 (each within the scatter of the next); then compound 1; then compound 2.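

In this assay the step with dimethylamino in place of hydrogen on this aromatic carbon is a 1.1-fold lower number from compound 3 to compound 4 (0.05 log units; within the scatter) and so shows that the position, meta to a 4-methylpiperazin-1-yl group, takes dimethylamino with no change beyond the scatter. No measurement at hand offers an explanation for this result.

As far as these compounds go, whether methoxy, a carboxylic acid or an amine on a longer chain at this aromatic carbon would also stay within the scatter of compound 3 remains open. Also open, from the compounds shown here alone, is whether dimethylamino here gives the same outcome with another group in place of the 4-methylpiperazin-1-yl group.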